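This account rests on a few compounds, and the source may have more. Where it says the series, first, only, none or still open, it means among the compounds named here.

In a functional assay on UACC-62 cells (Homo sapiens) for cytotoxicity, read by sulforhodamine B assay (a lower number here means a stronger inhibitor of growth, a higher number a weaker inhibitor of growth), compound 1 (`CC1=CC[C@@H]([C@@](C)(O)CCCC(C)(C)NC(=S)N/N=C\c2ccc(O)cc2)CC1`) gives 40100 nM. Compound 2 (`CC1=CC[C@@H]([C@@](C)(O)CCCC(C)(C)NC(=S)N/N=C\c2ccccc2Cl)CC1`) reads > 100000 nM, which is a limit and not a number. Compound 2 therefore stands at the limit of > 100000 nM in this assay, at which 1 of the 2 values shown sits. Compound 3 (`CC1=CC[C@@H]([C@@](C)(O)CCCC(C)(C)NC(=S)N/N=C\c2ccc(Cl)cc2)CC1`) differs from it as follows: 4-chlorophenyl in place of 2-chlorophenyl on a carbon with a double bond to nitrogen, with 4-chlorophenyl in place of 2-chlorophenyl on a carbon with a double bond to nitrogen. Among the compounds with values here, only one measured step bears on this change: an at least 2.4-fold higher number from compound 1 to compound 2 (0.39 log units; beyond the scatter), beyond the scatter, with 2-chlorophenyl in place of 4-hydroxyphenyl on that same carbon. Within the data shown here, no measured step isolates the exchange of the two chlorophenyl groups, so its size remains uncertain. A modest fall in the number is expected in this assay, leaving compound 3 on the weak side, near compound 1 at 40100 nM. The expected step runs an at least 1.4-fold lower number from compound 2 to compound 3 (0.15 log units; that floor lies within the scatter). For compound 3 the estimated value is 70000 nM, within an expected range of 30000 nM to 100000 nM.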

Compound 3, concentration for total growth inhibition: 13800 nM
Beside the measured number, compound 3's estimate is 5.1-fold (0.71 log units) above it; measured number below the stated range.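

In this assay, exchanging 2-chlorophenyl for 4-chlorophenyl on the carbon with a double bond to nitrogen gives an at least 7.2-fold lower number from compound 2 to compound 3 (0.86 log units; beyond the scatter), so with the same atoms joined differently, the place of the chlorine on this ring decides much of the growth inhibition. Compound 2 gives a limit and not a number, so this step is only a floor: the limit of > 100000 nM in this assay, at which 1 of the 3 values shown sits. With chloro in place of hydroxy on an aromatic carbon, the series shows a 2.9-fold lower number from compound 1 to compound 3 (0.46 log units; beyond the scatter), so the weak reading of compound 2 does not follow simply from the loss of the hydroxy group.

From the compounds shown here alone, whether 3-chlorophenyl would read nearer to 2-chlorophenyl or to 4-chlorophenyl stays open. Also open, going by these compounds, is whether the gain is particular to chloro or extends to groups such as methoxy, an amine or a carboxylic acid at this place.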